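Adding a Second Trifluoromethyl to a Weakly Cytotoxic Amide

The compounds below may be only part of what the source reports. "The series", "measured", "known", "first", "only" and "open" are said of these compounds alone.

Compound 2 `O=C(Nc1ccc(NS(=O)(=O)C(F)(F)F)c(F)c1)c1cccc(C(F)(F)F)c1` is one of two compounds assessed in an ADME assay on HEK293 cells (Homo sapiens) for cytotoxicity, read by MTT assay, with a stated time of 48 h; a higher number here means a weaker inhibitor, a lower number a stronger inhibitor; compound 2 gives 152000 nM, the only number shown. Compound 1 `COc1cc(NC(=O)c2cc(C(F)(F)F)cc(C(F)(F)F)c2)ccc1NS(=O)(=O)C(F)(F)F` reaches only a limit of the assay, > 250000 nM. Compound 3 `O=C(Nc1ccc(NS(=O)(=O)C(F)(F)F)c(F)c1)c1cc(C(F)(F)F)cc(C(F)(F)F)c1` differs from compound 2 by trifluoromethyl in place of hydrogen on an aromatic carbon. Among the measured compounds shown here, no measured pair shows this change. Compound 1 already carries two trifluoromethyl groups and sits at the limit of > 250000 nM in this assay, at which 1 of the 2 values shown sits, which suggests a weak inhibitor. The step of a 1.3-fold higher number from compound 2 to compound 3 (0.12 log units; within the scatter) is expected to be small and toward weaker inhibition. Compound 3 is estimated at 200000 nM, within 100000 nM to 300000 nM.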

Compound 3, half-maximal inhibitory concentration: 164000 nM
For compound 3 the middle estimate is 1.2-fold (0.09 log units) above the measured one; measured number inside the range.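

In this assay, among the compounds shown here, the first measured pair for this change puts a second trifluoromethyl on the aromatic carbon with a 1.1-fold higher number from compound 2 to compound 3 (0.03 log units; within the scatter), so at this position the added group leaves the number unchanged within the scatter. Fluoro in place of methoxy gives an at least 1.5-fold lower number from compound 1 to compound 3 (0.18 log units; that floor lies within the scatter), and that floor cannot separate the two compounds. Compound 1 is the one compound that reaches a limit of the assay, not a number: the limit of > 250000 nM in this assay, at which 1 of the 3 values shown sits.

Still open, as far as these compounds go, is whether an amine or a carboxylic acid on this aromatic carbon would shift the number beyond the scatter.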